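Adding a Diethylamino Chain to Compound 3

The source may hold more compounds than are shown below. What is called first, only, known or untested is meant among the compounds shown, and "the series" means these compounds.

In an ADME assay for permeability, using PAMPA, with a stated time of 4 h, at pH 5.5 (on this read-out lower numbers stand for lower permeability and higher numbers for higher permeability), compound 3 `CN(C[C@H]1Cc2ncccc2CN1)[C@H]1CCCc2cccnc21` gives 460 nm/s, the higher of the two numbers available. It stands well beyond the scatter from compound 1 `NCCCCN(C[C@H]1Cc2cccnc2CN1)[C@H]1CCCc2cccnc21`, which gives 2 nm/s. The entry for compound 2 `NCCCCN(C[C@@H]1Cc2cccnc2CN1)[C@H]1CCCc2cccnc21` reads "not determined" (no result reported). Compound 4 `CCN(CC)CCCCN(C[C@H]1Cc2ncccc2CN1)[C@H]1CCCc2cccnc21` differs from compound 3 as follows: 3-(diethylamino)propyl in place of hydrogen on a saturated chain carbon bound to an amine nitrogen, which turns a methyl into 4-(diethylamino)butyl. For the measured compounds named here, no measured step isolates this change, and the core of compound 1 is not that of compound 3. Even so, compound 1, which also carries a long amine-bearing chain, sits at 2 nm/s, so a large fall beyond the scatter is expected in this assay. The expected change is a 23-fold lower number from compound 3 to compound 4 (1.36 log units; beyond the scatter). Compound 4 is estimated at 20 nm/s, within an expected range of 3 nm/s to 120 nm/s.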

Compound 4, apparent permeability: 3 nm/s
Beside the measured number, compound 4's estimate is 6.7-fold (0.82 log units) above it; the range from low to high includes it.
By their numbers in this assay, from the lowest: compounds 1 and 4 (each within the scatter of the next); then compound 3.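

In this assay, the position on a saturated chain carbon bound to an amine nitrogen proves highly sensitive to this change: 3-(diethylamino)propyl in place of hydrogen gives a 150-fold lower number from compound 3 to compound 4 (2.19 log units; beyond the scatter) on an otherwise unchanged structure. For the compounds shown here, this is the first step to isolate a single change at this position, turning methyl into 4-(diethylamino)butyl. Nothing available bears on the cause of this fall.

Whether the chain's length or its terminal diethylamino group accounts for the step remains open. Also open, on these data alone, is how an ethyl group, a butyl chain without an amine, or a chain ending in a carboxylic acid would read at this position.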